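Adding a fluoro group to compound 3

The source may hold more compounds than are shown below. What is called first, only, known or untested is meant among the compounds shown, and "the series" means these compounds.

In a functional assay on HT-29 cells (Homo sapiens) for inhibition, read by MTT assay, with a stated time of 72 h (on this read-out higher numbers stand for weaker inhibition and lower numbers for stronger inhibition), compound 1 `COc1cccc(/C=C/C(=O)Nc2cc(OC)c(OC)c(OC)c2)c1` gives 44100 nM and compound 2 `COc1cc(NC(=O)/C=C/c2cccc(OCc3ccccc3)c2)cc(OC)c1OC` gives 3600 nM as the lowest number. Compound 3 `C=C(Br)C(=O)Nc1cccc(/C=C/C(=O)Nc2ccccc2)c1` gives 16600 nM and stands second highest of the three. Compound 4 `C=C(Br)C(=O)Nc1cccc(/C=C/C(=O)Nc2ccc(F)cc2)c1` differs from compound 3 by fluoro in place of hydrogen on an aromatic carbon, para to a large group, with fluoro in place of hydrogen on an aromatic carbon as the full count. Among the measured compounds shown here, the only measured step of a 12-fold lower number from compound 1 to compound 2 (1.09 log units; beyond the scatter) is large, but it places phenyl on a saturated chain carbon bound to an oxygen, a different change, and no measured step involves fluoro. No step beyond the scatter is therefore expected in this assay for this change. An estimated 1.2-fold lower number from compound 3 to compound 4 (0.07 log units; within the scatter) is the working figure. For compound 4 the expected value is 14000 nM with 7000 nM to 28000 nM as the estimated range.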

Compound 4, half-maximal inhibitory concentration: 36600 nM
Compound 4: middle estimate off by 2.6-fold (0.42 log units), on the low side; the whole stated range lies below it.
By their numbers in this assay, from the lowest: compound 2; then compound 3; then compounds 4 and 1 (each within the scatter of the next).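

In this assay the change from phenyl to 4-fluorophenyl is not silent: the step of a 2.2-fold higher number from compound 3 to compound 4 (0.34 log units; beyond the scatter) goes towards weaker inhibition. Among the compounds shown here, this is the first reading on this aromatic ring of compound 3, and it shows that a single fluoro, para to a large group, is enough to move the number. No measurement available here accounts for the shift. As far as these compounds go, whether the weakening is particular to fluoro stays open, as does the outcome with chloro, methoxy or an amine at this position.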